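The source may report more compounds than this note shows. Statements on the series, on what has been measured and on what is new or still open speak of the compounds shown alone.

Measured so far: compound 1 `CNC(=O)c1cc(Oc2ccc(NC(=O)c3cc4cccnc4n(-c4ccc(F)cc4)c3=O)cc2)ccn1` gives 2910 nM in a functional assay on U-87MG ATCC cells for antiproliferative activity against U-87 MG (Homo sapiens), read by MTT assay, with a stated time of 72 h; a higher number here means a weaker inhibitor, a lower number a stronger inhibitor; compound 2 `CCNC(=O)c1cc(Oc2ccc(NC(=O)c3cc4cccnc4n(-c4ccccc4)c3=O)cc2)ccn1` gives 2650 nM; compound 3 `CCNC(=O)c1cc(Oc2ccc(NC(=O)c3cc4cccnc4n(-c4ccc(F)cc4)c3=O)cc2)ccn1` gives 1130 nM.

Compound 3 arises from compound 1 by methyl in place of hydrogen on a saturated chain carbon bound to an amide-type nitrogen and the step is a 2.6-fold lower number from compound 1 to compound 3 (0.41 log units; beyond the scatter). Compound 3 also arises from compound 2 through a 2.3-fold lower number from compound 2 to compound 3 (0.37 log units; beyond the scatter). The difference between the cores of compound 1 and compound 2 is not broken down here.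

Compound 4 `CCCNC(=O)c1cc(Oc2ccc(NC(=O)c3cc4cccnc4n(-c4ccccc4)c3=O)cc2)ccn1` is not yet measured. It arises from compound 2 by methyl in place of hydrogen on a saturated chain carbon, two bonds along the chain from an amide-type nitrogen. This is the same kind of change as that from compound 1 to compound 3, not the same: there the place was a saturated chain carbon bound to an amide-type nitrogen, here it is two bonds along the chain from that nitrogen. Resting on the one lengthening already seen, a 2.6-fold lower number from compound 1 to compound 3 (0.41 log units; beyond the scatter), a smaller gain is expected, a 1.4-fold lower number from compound 2 to compound 4 (0.14 log units; within the scatter). Compound 4 is therefore estimated at 1900 nM, between 900 nM and 4000 nM.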

Compound 4, half-maximal inhibitory concentration: 1510 nM
Compound 4: middle estimate off by 1.3-fold (0.10 log units), on the high side; measured number inside the range.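

In this assay, the added methyl gives a 1.8-fold lower number from compound 2 to compound 4 (0.24 log units; within the scatter), and this step cannot be told apart from the earlier one on the other core: the same change on two cores in this assay, a 2.6-fold lower number (0.41 log units; beyond the scatter) from compound 1 to compound 3 and a 1.8-fold lower number (0.24 log units; within the scatter) from compound 2 to compound 4, 1.5-fold (0.17 log units) apart, within the scatter of two such steps

The two results are thus compatible with the change carrying over between the core of compound 1 and the core of compound 2, but two pairs do not establish that it holds on other cores. The step on compound 2 taken alone stays within the scatter, and the two methyls enter at different places, one on a saturated chain carbon bound to the amide-type nitrogen and the other two bonds along the chain.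

The compounds shown leave open how propyl behaves on the core of compound 1. They also leave open whether a butyl chain or a cyclopropyl group in place of propyl would continue the trend.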